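The source may report more compounds than this note shows. Statements on the series, on what has been measured and on what is new or still open speak of the compounds shown alone.

Working notes on the series

Compound 3 `CN(C)c1ccc2c(c1)N(S(C)(=O)=O)CC2CCl` gives 15000 nM in a functional assay on UV4 cells (Cricetulus griseus) for cytotoxicity, with a stated time of 4 h (a higher number here means a weaker inhibitor, a lower number a stronger inhibitor), the highest number among the three measured compounds. Compound 1 `CS(=O)(=O)N1CC(CCl)c2ccc(O)cc21` gives 1900 nM in this assay, and compound 2 `CNc1ccc2c(c1)N(S(C)(=O)=O)CC2CCl` gives 4100 nM. The steps run upward through the set: a 2.2-fold higher number from compound 1 to compound 2 (0.33 log units; beyond the scatter), a 3.7-fold higher number from compound 2 to compound 3 (0.56 log units; beyond the scatter), and overall a 7.9-fold higher number from compound 1 to compound 3 (0.90 log units; beyond the scatter).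

Compound 4 `CS(=O)(=O)N1CC(CCl)c2ccc(S)cc21` is not yet measured. The change from compound 3 to compound 4 is sulfanyl in place of dimethylamino on an aromatic carbon. Among the compounds with values here, no measured pair in this set exchanges hydroxy for sulfanyl, so the step from compound 3 bears only indirectly on the measured steps. The closest guide is the reverse of the step from compound 1 to compound 3, where removing dimethylamino in favour of hydroxy accounts for a large part of the spread in this assay; sulfanyl shares a hydrogen-bond donor and a single heavy atom with hydroxy. The number for compound 4 is therefore expected to move downward, by an estimated 5.4-fold lower number from compound 3 to compound 4 (0.73 log units; beyond the scatter), toward the value of compound 1. Compound 4 is estimated at 2800 nM, with a range of 900 nM to 8000 nM.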

Compound 4, half-maximal inhibitory concentration: 124000 nM
Compound 4: middle estimate off by 44-fold (1.65 log units), on the low side; the measured number lies above the stated range.
By their numbers in this assay, from the lowest: compound 1; then compound 2; then compound 3; then compound 4.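

In this assay, this aromatic carbon tolerates the exchange of hydroxy for sulfanyl poorly, with a 65-fold higher number from compound 1 to compound 4 (1.81 log units; beyond the scatter), the largest step in the set. Sulfanyl also gives a higher number than either amine, with a 30-fold higher number from compound 2 to compound 4 (1.48 log units; beyond the scatter) and an 8.3-fold higher number from compound 3 to compound 4 (0.92 log units; beyond the scatter), which places it at the top of the order hydroxy, methylamino, dimethylamino, sulfanyl. Sulfanyl has 1 hydrogen-bond donor and dimethylamino has 0, so compound 4 shows that a donor on this carbon does not by itself give a lower number.

No measurement shown here accounts for the rise. As far as these compounds go, whether it is particular to sulfanyl, or also appears with methylsulfanyl or an unsubstituted amino group on this carbon, remains open.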